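Trimming the Ethyl to Methyl on the Shared Core

The source may hold more compounds than are shown below. What is called first, only, known or untested is meant among the compounds shown, and "the series" means these compounds.

Compound 1 `CCC(=O)N[C@@H]1CCCc2c1cncc2N1C(=O)c2ccc(Cl)cc2[C@@H]1C` and compound 2 `CC(=O)N[C@@H]1CCCc2c1cncc2N1C(=O)c2ccc(Cl)cc2[C@@H]1C` share a core with compound 3 `CCC(=O)N[C@@H]1CCCc2c1cncc2N1C(=O)c2ccc(Cl)cc2[C@H]1CC` and the not yet measured compound 4 `CCC(=O)N[C@@H]1CCCc2c1cncc2N1C(=O)c2ccc(Cl)cc2[C@H]1C`. All three measured compounds were run in an ADME assay on microsomes from liver (Mus musculus) for metabolic stability, read by LC-MS, using NADPH, with stated times of 10 min and 30 min; a higher number here means faster removal of the compound, a lower number slower removal. In this assay compound 1 gives < 20.2 mL/min/kg, a value that is a limit of the assay rather than a number. Compound 2 likewise gives < 20.2 mL/min/kg, again a limit of the assay. Among the compounds with values here, compound 3 is the only one with a number, giving 44.9 mL/min/kg in this assay.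

The change from compound 1 to compound 2 is hydrogen in place of methyl on a saturated chain carbon bound to a carbonyl carbon and the step is a step that the two limits leave unreadable from compound 1 to compound 2, unreadable since both ends sit at the limit of < 20.2 mL/min/kg in this assay, at which 2 of the 3 values shown sit. The same kind of change leads from compound 3 to compound 4, namely (hydrogen in place of methyl on a saturated chain carbon bound to a saturated ring carbon), though what surrounds the place differs: in the first pair the saturated chain carbon is bound to a carbonyl carbon, in the second to a saturated ring carbon. The difference between the cores of compound 1 and compound 3 is not broken down here.

For compound 4 in this assay a modest downward step is expected, a 1.7-fold lower number from compound 3 to compound 4 (0.24 log units; within the scatter), resting on compound 3 at 44.9 mL/min/kg. The value of compound 1 in this assay is a limit of the assay. Compound 4 is thus estimated to fall near 26 mL/min/kg, between 12 mL/min/kg and 52 mL/min/kg.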

Compound 4, clearance: 45.6 mL/min/kg
For compound 4 the middle estimate is 1.8-fold (0.24 log units) below the measured one, and the stated range covers the measured number.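

In this assay the trim on the core of compound 3 gives a 1.0-fold higher number from compound 3 to compound 4 (0.01 log units; within the scatter), so hydrogen in place of methyl on a saturated chain carbon bound to a saturated ring carbon has no readable effect on clearance here. This single readable step cannot be set against the same kind of change on the core of compound 1, where the place is a saturated chain carbon bound to a carbonyl carbon, and steps between two limits cannot be read; the compounds therefore show neither that the change carries from one core to the other nor that it fails to: the limit of < 20.2 mL/min/kg in this assay, at which 2 of the 4 values shown sit. The core does matter to the level of the read-out, since compound 1 stands at a limit of the assay and the step of an at least 2.2-fold higher number from compound 1 to compound 4 (0.35 log units; beyond the scatter) can be traced to the stereocentre at a saturated ring carbon alone: the fact that compounds 1 and 4 differ only in the configuration as drawn.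

Going by these compounds, what remains open is how the ethyl group would read in the configuration drawn in compound 1, where a number might fall under the limit of the assay. Also open, on these data alone, is whether a longer chain such as propyl, or an amine, at that saturated chain carbon would follow the same flat step seen with ethyl and methyl.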